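A few compounds are considered here, and "the series" means these few. Any claim that something is new, unique, unknown or untested is made for them only; others in the source may bear on it.

Measured compounds:
compound 1 `CC(=O)c1ccc2c(c1)N(C1=CCCC1=O)CC(C)(C)S2` — 77%
compound 2 `CC1(C)CN(C2=CCCC2=O)c2cc(N)ccc2S1` — "not determined" (no result reported)

In a functional assay on aorta (Rattus norvegicus, strain Wistar), in the presence of a further agent that is not named here (on this read-out lower numbers stand for smaller maximal responses and higher numbers for larger maximal responses), compound 1 reaches 77%. Compound 2 was taken into the same assay, but no number came back for it, so compound 2 stands nowhere on the scale of this assay: of the two measured compounds, only compound 1 carries a value. Compound 3 `CCc1ccc2c(c1)N(C1=CCCC1=O)CC(C)(C)S2` has not been measured. The change from compound 2 to compound 3 is ethyl in place of amino on an aromatic carbon. Going by the values given here, no pair of measured compounds differs in only one place, so no step size from the data can be carried over. For the change from compound 2 to compound 3 in this assay, a step in either direction that stays within the usual scatter is expected, with the value of compound 1 as the only anchor. Compound 3 is expected to reach about 75%, with a range from 55% to 95%.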

Compound 3, largest response reached (Emax), in percent of the reference or control that the assay uses: 69%
Compound 3: middle estimate off by 6 percentage points, on the high side, within the range that was stated.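

Going by these compounds alone, compound 3 supplies the first pair in this set that differs in only one place, and in this assay it gives a number 8 percentage points lower from compound 1 to compound 3 (within the scatter). Acetyl and ethyl on this aromatic carbon, meta to a fused ring and para to a fused ring, are therefore not separated by this read-out, and with either group the shared core still gives a measurable maximal response. No measurement at hand bears on why these two groups compare as they do.

From the compounds shown here alone, the step from compound 2 to compound 3 cannot be read, since compound 2 has no number, so what amino does at this position stays unknown. Also open, going by these compounds, is whether a carboxylic acid, a dimethylamine or a longer chain such as butyl on the same carbon would stay within the scatter of these two compounds.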